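The source may report more compounds than this note shows. Statements on the series, on what has been measured and on what is new or still open speak of the compounds shown alone.

Compound 2 `Cc1nnc(CN(C)C)n1-c1ccc(Cl)cc1C(=O)c1ccccc1` gives 45 mg/kg in a functional assay on the whole organism (strain CF-1) for inhibition, with Mus musculus as the target (a lower number here means that less compound is needed, a higher number that more compound is needed for the effect), and compound 3 `CCNCc1nnc(C)n1-c1ccc(Cl)cc1C(=O)c1ccccc1` gives 45 mg/kg, so that the step of no change at the digits printed from compound 2 to compound 3 (within the scatter). Compound 1 `CN(C)Cc1nnc(-c2ccco2)n1-c1ccc(Cl)cc1C(=O)c1ccccc1` gives only a limit, > 100 mg/kg. The step of an at least 2.2-fold lower number from compound 1 to compound 2 (0.34 log units; beyond the scatter); one of the three values sits at the limit of > 100 mg/kg in this assay, at which 1 of the 3 values shown sits. Compound 4 `Cc1nnc(CN(C)C)n1-c1ccc(Cl)cc1C(=O)c1ccccc1Cl` differs from compound 2 by chloro in place of hydrogen on an aromatic carbon. Neither measured step touches that part of the molecule: one exchanges a group on an aromatic carbon of the shared core, the other the amine on a saturated chain carbon. For the measured compounds named here, no measured step therefore bears directly on this change, and no step beyond the scatter is expected in this assay. Compound 4 is estimated at 35 mg/kg, with a range from 12 mg/kg to 100 mg/kg, an expected step of a 1.3-fold lower number from compound 2 to compound 4 (0.11 log units; within the scatter).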

Compound 4, dose for half-maximal effect: 50 mg/kg
For compound 4 the middle estimate is 1.4-fold (0.15 log units) below the measured one, within the range that was stated.
By their numbers in this assay, from the lowest: compounds 2, 3 and 4 (each within the scatter of the next). At a limit, above all of these: compound 1.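

Among the compounds shown, this is the only step that touches the phenyl group, and phenyl to 2-chlorophenyl in this assay gives a 1.1-fold higher number from compound 2 to compound 4 (0.05 log units; within the scatter). Chloro in place of hydrogen on this aromatic carbon, ortho to a large group, therefore moves the number no further than the scatter. Nothing shown accounts for this result.

As far as these compounds go, whether a methoxy group or a nitrile at this position would also stay within the scatter remains open. So does whether chloro would behave alike alongside the ethylamino group of compound 3.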